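The compounds below may be only part of what the source reports. "The series", "measured", "known", "first", "only" and "open" are said of these compounds alone.

Measured so far:
compound 1 `CC(C)C[C@H](N)CCN(C(=O)[C@@H]1C[C@H]1c1ccccc1)c1ccc(-c2ccccc2)cc1`, 3 nM
compound 2 `CC[C@H](C)[C@H](N)CN(C(=O)[C@@H]1C[C@H]1c1cccc(Cl)c1)c1ccc(-c2ccccc2)cc1`, 2200 nM

Both compounds were tested in a functional assay for agonist activity at G protein-coupled receptor 88 (Homo sapiens), read by HTRF and cAMP accumulation; on this read-out lower numbers stand for an effect already at smaller amounts and higher numbers for an effect only at larger amounts of compound. Compound 1 gives 3 nM, whereas compound 2 gives 2200 nM, the higher of the two numbers, and the gap between them lies far beyond the usual scatter. Within the data shown here, the two compounds differ in more than one place, so these two numbers show only that compound 2 needs much more substance than compound 1 for the same effect; nothing can be said about which of the differences accounts for it.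

The next compound, compound 3 `CC[C@H](C)[C@H](N)CN(C(=O)[C@@H]1C[C@H]1c1ccncc1)c1ccc(-c2ccccc2)cc1`, keeps the shared core of compound 2 and alters a single group: pyridin-4-yl in place of 3-chlorophenyl on a saturated ring carbon. Among the measured compounds shown here, no pair of measured compounds shows what this exchange does on its own, so there is no measured step to lean on. The change is expected to shift the number modestly upward, a 1.8-fold higher number from compound 2 to compound 3 (0.26 log units; within the scatter), though a result within the scatter would not surprise. Compound 3 is therefore expected to give about 4000 nM, with a likely range from 900 nM to 18000 nM.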

Compound 3, half-maximal effective concentration: 1500 nM
Compound 3: the middle estimate sits 2.7-fold (0.43 log units) above what was measured; low and high end bracket the measured number.
By their numbers in this assay, from the lowest: compound 1; then compounds 3 and 2 (each within the scatter of the next).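

In this assay, pyridin-4-yl in place of 3-chlorophenyl on a saturated ring carbon of the three-membered ring gives a 1.5-fold lower number from compound 2 to compound 3 (0.17 log units; within the scatter), so this assay does not tell the two groups apart. Among these compounds, this is the first measured exchange at this position, and it shows that a chlorine-bearing ring of carbon only and a ring with one hetero atom and one hydrogen-bond acceptor can occupy this place with no difference beyond the usual scatter of repeated measurements, at least on this core with its amine side chain. No independent measurement is available to explain why the two groups give such similar numbers.

A single step cannot show whether this position generally accepts different groups, nor whether the same exchange would give a similar result on another core, such as that of compound 1. Also open, going by these compounds, is what other groups would do at this position on the core of compound 3, for example pyridin-3-yl, a phenyl ring carrying a methoxy group or a carboxylic acid, or a simple methyl group.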